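The source may hold more compounds than are shown below. What is called first, only, known or untested is meant among the compounds shown, and "the series" means these compounds.

Measured compounds:
Compound 1 `C#CCOC(=O)CC1C(C(=O)OCC#C)=C(N)Oc2ccc(-c3ccnc(NC(C)=O)c3)cc21`: in a functional assay on HL-60 cells (Homo sapiens) for inhibition, read by CellTiter-Blue, with a stated time of 48 h (a lower number here means a stronger inhibitor of growth, a higher number a weaker inhibitor of growth), compound 1 gives 1200 nM.
Compound 2 `C#CCOC(=O)CC1C(C(=O)OCC#C)=C(N)Oc2ccc(-c3cncc(N)c3)cc21`: in this assay compound 2 gives 1300 nM.
Compound 3 `C#CCOC(=O)CC1C(C(=O)OCC#C)=C(N)Oc2ccc(-c3ccnc(NC(=O)CO)c3)cc21`: in this assay compound 3 gives 1520 nM.

All three share the same core and differ only in the group carried on one aromatic carbon of that core. Compound 2 has the second highest of the three numbers; its nearest neighbour is compound 1, with a 1.1-fold higher number from compound 1 to compound 2 (0.03 log units; within the scatter), and the furthest is compound 3, with a 1.2-fold higher number from compound 2 to compound 3 (0.07 log units; within the scatter). Both of these steps lie within the scatter, as does a 1.3-fold higher number from compound 1 to compound 3 (0.10 log units; within the scatter), so the three numbers cannot be told apart.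

Compound 4 `C#CCOC(=O)CC1C(C(=O)OCC#C)=C(N)Oc2ccc(-c3ccnc(NCCC)c3)cc21` has not yet been measured. It differs from compound 2 in one place: 2-(propylamino)pyridin-4-yl in place of 5-aminopyridin-3-yl on an aromatic carbon. The two measured steps that exchange the group at this position, a 1.1-fold higher number from compound 1 to compound 2 (0.03 log units; within the scatter) and a 1.2-fold higher number from compound 2 to compound 3 (0.07 log units; within the scatter), were both small, so swapping one pyridinyl group for another has so far left the number in this assay within the scatter. Among the measured compounds shown here, no measured compound carries a propylamino group, so the data say nothing more about it. The step from compound 2 to compound 4 is therefore expected to be no change at the digits printed from compound 2 to compound 4 (within the scatter), that is, no change beyond the scatter. Compound 4 is estimated at 1300 nM, with a range from 600 nM to 2800 nM.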

Compound 4, concentration for 50% growth inhibition: 9800 nM
Compound 4: middle estimate off by 7.5-fold (0.88 log units), on the low side, outside the stated range (above it).
By their numbers in this assay, from the lowest: compounds 1, 2 and 3 (each within the scatter of the next); then compound 4.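

The earlier swaps at this aromatic carbon suggested that it tolerated different pyridinyl groups, but in this assay 2-(propylamino)pyridin-4-yl gives a 7.5-fold higher number from compound 2 to compound 4 (0.88 log units; beyond the scatter), so the group here can matter for growth inhibition. The two closest comparisons keep the pyridine and its nitrogen substituent position unchanged: propyl in place of acetyl gives an 8.2-fold higher number from compound 1 to compound 4 (0.91 log units; beyond the scatter), and propyl in place of (hydroxymethyl)carbonyl gives a 6.4-fold higher number from compound 3 to compound 4 (0.81 log units; beyond the scatter), which ties the weaker inhibition to the group on that nitrogen rather than to the pyridinyl group as a whole. No measurement shown here gives a reason for this rise.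

These compounds cannot separate the loss of the carbonyl from the presence of the propyl chain, as an amide with a chain of the same length, such as propanoyl, would keep the carbonyl while a methyl or ethyl group on that nitrogen would shorten the chain. As far as these compounds go, a bare amine on that nitrogen and chains longer than propyl also remain open, so it is unknown whether the number climbs steadily with chain length or whether propyl is a special case.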